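The source may hold more compounds than are shown below. What is called first, only, known or untested is meant among the compounds shown, and "the series" means these compounds.

This account follows the step from compound 3 `COc1cc(-c2ccnc3cc(-c4ccc5cnn(C)c5c4)nn23)cc(OC)c1OC` to compound 4 `COc1cc(-c2ccnc3cc(-c4ccc(C(F)(F)F)cc4)nn23)cc(OC)c1OC` in a functional assay on MCF7 cells (Homo sapiens) for inhibition, read by CCK-8 assay, with a stated time of 48 h; on this read-out higher numbers stand for weaker inhibition and lower numbers for stronger inhibition. Among the numbers shown, compound 3 gives the highest, 279 nM. Its nearest neighbour is compound 1 `COc1cc(-c2ccnc3cc(-c4ccc(C)cc4)nn23)cc(OC)c1OC`, which in this assay gives 47 nM, so that a 5.9-fold higher number from compound 1 to compound 3 (0.77 log units; beyond the scatter). In this assay compound 2 `COc1cc(-c2ccnc3cc(-c4ccc(C(C)(C)C)cc4)nn23)cc(OC)c1OC` gives a limit rather than a number, > 10000 nM (the limit of > 10000 nM in this assay, at which 1 of the 3 values shown sits). The change to compound 4 is 4-(trifluoromethyl)phenyl in place of 1-methyl-1H-indazol-6-yl on an aromatic carbon. Within the data shown here, two measured steps bear on it: an at least 210-fold higher number from compound 1 to compound 2 (2.32 log units; beyond the scatter), and an at least 35-fold lower number from compound 2 to compound 3 (1.55 log units; beyond the scatter). Compound 4 carries a 4-(trifluoromethyl)phenyl group, a substituted phenyl like the 4-methylphenyl of compound 1 and the 4-(tert-butyl)phenyl of compound 2, and the numbers for those two compounds lie far apart. The step in this assay is therefore expected to run towards a higher number, modest in size and short of the limit. Compound 4 is expected to give 1500 nM, between 250 nM and 9000 nM. That estimate would mean a 5.4-fold higher number from compound 3 to compound 4 (0.73 log units; beyond the scatter).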

Compound 4, half-maximal inhibitory concentration: 2440 nM
Beside the measured number, compound 4's estimate is 1.6-fold (0.21 log units) below it; the measured number falls inside the stated range.
By their numbers in this assay, from the lowest: compound 1; then compound 3; then compound 4. At a limit, above all of these: compound 2.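

In this assay, the groups at this aromatic carbon no longer fall into just two extremes, since a third 4-substituted phenyl gives a number between those of compound 1 and compound 2: trifluoromethyl in place of methyl gives a 52-fold higher number from compound 1 to compound 4 (1.72 log units; beyond the scatter), and trifluoromethyl in place of tert-butyl gives an at least 4.0-fold lower number from compound 2 to compound 4 (0.61 log units; beyond the scatter). The second of these steps is read against a limit, which is what compound 2 gives: the limit of > 10000 nM in this assay, at which 1 of the 4 values shown sits. The change from the 1-methyl-1H-indazol-6-yl group to 4-(trifluoromethyl)phenyl gives an 8.7-fold higher number from compound 3 to compound 4 (0.94 log units; beyond the scatter), so compound 3 now stands on the lower side of one substituted phenyl, while compound 1 still gives the lowest number shown.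

The compounds shown leave open whether this order holds for other groups on the phenyl ring, such as methoxy, chlorine or an amine. Going by these compounds, whether an unmethylated 1H-indazol-6-yl group would keep the number of compound 3 also stays open.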